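From Methoxy to Nitro on an Aromatic Carbon

The source may report more compounds than this note shows. Statements on the series, on what has been measured and on what is new or still open speak of the compounds shown alone.

For the measured compounds named here, in a functional assay on HeLa cells (Homo sapiens) for inhibition, read by MTT assay, with a stated time of 72 h (on this read-out lower numbers stand for stronger inhibition and higher numbers for weaker inhibition), compound 1 (`COc1ccc(C(=O)/C=C/c2cc(OC)c(OC)cc2OC)cc1`) gives 37600 nM, the only true number available so far. Compound 2 (`COc1cc(OC)c(OC)cc1/C=C/C(=O)c1cc(Cl)ccc1O`) gives > 150000 nM, which is a limit of the assay and not a number.

Compound 3 (`COc1cc(OC)c(OC)cc1/C=C/C(=O)c1ccc([N+](=O)[O-])cc1`) keeps the core of compound 1 but has nitro in place of methoxy on an aromatic carbon, para to a large group (nitro in place of methoxy on an aromatic carbon). On these data alone, its value in this assay is still unknown.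

One measured step offers a guide: an at least 3.9-fold higher number from compound 1 to compound 2 (0.60 log units; beyond the scatter). That change also removes the methoxy-bearing group of compound 1, although it puts a different group in its place, so it is only a loose parallel. Since one end of that step is a limit, its true size is not known, and a single step cannot establish a trend.

The expected change is a small one toward weaker inhibition, close to the usual scatter: a 2.1-fold higher number from compound 1 to compound 3 (0.33 log units; beyond the scatter). For compound 3 the estimated value is 80000 nM, with an expected range from 25000 nM to 150000 nM.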

Compound 3, half-maximal inhibitory concentration: > 150000 nM
Compound 3 ended at the assay's limit (the forecaster's own chance of this, stated with the estimate: 20%); middle value at least 1.8-fold (0.27 log units) from the limit.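

In this assay, this one replacement on an aromatic carbon, para to a large group, gives an at least 3.9-fold higher number from compound 1 to compound 3 (0.60 log units; beyond the scatter), so the change reaches past the usual scatter and leaves compound 3 at a limit of the assay. The earlier step to compound 2 replaced a whole group on the carbonyl carbon, whereas here only methoxy leaves and nitro enters, with the rest of compound 1 kept, so the loss of measurable inhibition can be tied to this single place. The full size of the step stays unknown because it ends at a limit rather than at a true number: the limit of > 150000 nM in this assay, at which 2 of the 3 values shown sit.

On these data alone, whether the loss comes from removing methoxy or from adding nitro stays open, and the shared core with only a hydrogen, an amine or a carboxylic acid at this place would help to separate the two. For the compounds shown here, it is also unclear whether any group at this place could give a lower number than compound 1, which still holds the only true value.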